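A few compounds are considered here, and "the series" means these few. Any claim that something is new, unique, unknown or untested is made for them only; others in the source may bear on it.

Compound 1 `CCCCC#Cc1cc2cn(C)c(=O)nc2o1`, compound 2 `CCCCCCCCCCC#Cc1cc2cn(C)c(=O)nc2o1` and compound 3 `CCCCCCC#Cc1cc2cn(C)c(=O)nc2o1` share one core and differ only in the length of the chain on the triple bond. In a functional assay on HEL cells (Homo sapiens) for cytotoxicity (a lower number here means that less compound is tolerated, a higher number that more compound is tolerated), compound 2 gives > 150000 nM, which is a limit. Compound 1 gives > 217000 nM, also a limit. Compound 3 gives > 194000 nM, again a limit. Compound 4 `CCCCCCCCCCC#Cc1cc2cn([C@@H]3O[C@H](CO)[C@@H](O)[C@H]3O)c(=O)nc2o1` keeps the chain of compound 2 but carries 3,4-dihydroxy-5-(hydroxymethyl)oxolan-2-yl in place of methyl on an aromatic nitrogen. Within the data shown here, no measured step touches that nitrogen, and the chain steps, a step that the two limits leave unreadable from compound 1 to compound 2 and a step that the two limits leave unreadable from compound 2 to compound 3, have no readable size. No shift beyond the scatter is therefore expected in this assay, in either direction. The expected change is an at least 1.1-fold lower number from compound 2 to compound 4 (0.06 log units; that floor lies within the scatter). For compound 4 the estimated value is 130000 nM, within an expected range of 40000 nM to 260000 nM.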

Compound 4, half-maximal cytotoxic concentration: 44000 nM
Compound 4: middle estimate off by 3.0-fold (0.47 log units), on the high side; the range from low to high includes it.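

In this assay, among these compounds, replacing methyl on the aromatic nitrogen with 3,4-dihydroxy-5-(hydroxymethyl)oxolan-2-yl gives the only readable step in the set, an at least 3.4-fold lower number from compound 2 to compound 4 (0.53 log units; beyond the scatter). It shows that, with the chain of compound 2 held fixed, a change at this nitrogen can move the number towards less compound tolerated, which the unreadable chain steps could not show. Compound 2 stands only at a limit, so this size is a floor: the limit of > 150000 nM in this assay, at which 1 of the 4 values shown sits.

On these data alone, whether the same exchange lowers the number on the shorter chains of compound 1 and compound 3 stays open. So does which part of the entering group carries the step, a question that a plain oxolan-2-yl or a 2-hydroxyethyl on that nitrogen would address.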